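Methyl on the thiophene of compound 1

The compounds below may be only part of what the source reports. "The series", "measured", "known", "first", "only" and "open" are said of these compounds alone.

Compound 1 `CCN(Cc1cccs1)C(=O)COc1ccc(C)cc1` is the reference point of this small amide pair. In an assay on HEK293 cells for agonist activity at transient receptor potential cation channel subfamily M member 8 (Homo sapiens), read by fluorescence and calcium flux, with a stated time of 15 min (on this read-out higher numbers stand for an effect only at larger amounts of compound and lower numbers for an effect already at smaller amounts), compound 1 gives 8 nM, the lower of the two numbers obtained so far. Within the data shown here, its only measured neighbour is compound 2 `CCN(Cc1cccs1)C(=O)COc1ccc(F)cc1`, which in this assay gives 422 nM; the single change, fluoro in place of methyl on an aromatic carbon of the other ring, brings a 53-fold higher number from compound 1 to compound 2 (1.72 log units; beyond the scatter).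

Compound 3 `CCN(Cc1ccc(C)s1)C(=O)COc1ccc(C)cc1` differs from compound 1 by methyl in place of hydrogen on an aromatic carbon, so that the thiophen-2-yl becomes 5-methylthiophen-2-yl, the new group sitting next to the ring sulfur. Among the measured compounds shown here, no measured step touches this five-membered ring; the one known step concerns a different ring and a different pair of groups, so it offers no direct guide to what a methyl entering here will do. With nothing pointing in either direction, the step is expected to remain within the scatter, estimated as a 1.5-fold higher number from compound 1 to compound 3 (0.18 log units; within the scatter). For the measured compounds named here, compound 3 is therefore expected at about 12 nM in this assay, within a range from 3 nM to 50 nM, the width reflecting that only one measured step is available.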

Compound 3, half-maximal effective concentration: 178 nM
Beside the measured number, compound 3's estimate is 15-fold (1.17 log units) below it, and the stated range ends below it.
By their numbers in this assay, from the lowest: compound 1; then compound 3; then compound 2.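

In this assay the five-membered ring proves sensitive to substitution: methyl in place of hydrogen on an aromatic carbon next to the ring sulfur gives a 22-fold higher number from compound 1 to compound 3 (1.35 log units; beyond the scatter) and so moves the number in the same direction as the change already seen on the other ring. Both single changes from compound 1 now raise the number beyond the scatter, the earlier one being a 53-fold higher number from compound 1 to compound 2 (1.72 log units; beyond the scatter) on the other ring, and compound 1 at 8 nM keeps the lowest number of the three. Nothing among the available data accounts for the rise at this position, so it stands as an observation only.

A chloro, an ethyl or a methoxy on this same carbon would show whether the rise belongs to methyl in particular or follows any group entering here. On these data alone, it also remains open how a methyl behaves on the other carbons of the five-membered ring, and whether hydrogen at this carbon is the only substituent compatible with a number as low as that of compound 1.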